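The source may hold more compounds than are shown below. What is called first, only, known or untested is meant among the compounds shown, and "the series" means these compounds.

Working notes on the series.

Going by the values given here, in a functional assay, with a stated time of 10 min (on this read-out lower numbers stand for stronger inhibition and higher numbers for weaker inhibition), three compounds have numbers so far. Compound 1 `CSc1nc(-c2cccs2)c(C#N)c(=O)n1C` gives 72 ug/mL in this assay. Compound 2 `CCOC(=O)c1cnn(-c2nc(-c3ccc(Cl)cc3)c(C#N)c(=O)n2C)c1N` gives 94 ug/mL in this assay. Compound 3 `CSc1nc(-c2cccc(O)c2O)c(C#N)c(=O)n1C` gives 37 ug/mL in this assay. Compound 2 stands at the highest number of the three: its gap to compound 1 lies within the usual scatter, so no order between these two is claimed, while its gap to compound 3 lies beyond the scatter, so compound 3 shows stronger inhibition than compound 2.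

Compound 4 `CCOC(=O)c1cnn(-c2nc(-c3ccco3)c(C#N)c(=O)n2C)c1N` has not yet been measured in this assay. It differs from compound 2 in one place: furan-2-yl in place of 4-chlorophenyl on an aromatic carbon. No measured pair shows this particular change, so its effect rests on no shown step. The step from compound 2 to compound 4 in this assay is expected to be small, a 1.1-fold higher number from compound 2 to compound 4 (0.03 log units; within the scatter), not beyond the scatter in either direction. Compound 4 is therefore estimated at 100 ug/mL in this assay, with a range from 50 ug/mL to 200 ug/mL.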

Compound 4, half-maximal inhibitory concentration: 104 ug/mL
Estimate against measurement, compound 4: 1.0-fold (0.02 log units) below; the measured number falls inside the stated range.
By their numbers in this assay, from the lowest: compounds 3, 1, 2 and 4 (each within the scatter of the next, the first and the last beyond it).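

Going by these compounds alone, this is the first one-place comparison: in this assay, furan-2-yl in place of 4-chlorophenyl gives a 1.1-fold higher number from compound 2 to compound 4 (0.04 log units; within the scatter), so the two compounds cannot be ordered. At this position, next to the ring nitrogen and ortho to a cyano group, the read-out therefore does not separate a six-membered aromatic ring of carbon only, bearing chlorine, from a five-membered aromatic ring with 1 hetero atom, although the two groups differ in size and in hydrogen-bond acceptors. Nothing available bears on why these two compounds stand so close.

As far as these compounds go, whether a much different group at this position, such as an amine, a carboxylic acid or a longer alkyl chain, would move the number remains open. Also open, from the compounds shown here alone, is whether the same change would read alike on the core of compound 1.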